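The source may report more compounds than this note shows. Statements on the series, on what has been measured and on what is new or still open speak of the compounds shown alone.

Measured compounds:
- compound 1, `CC1CCN(C2CCN(S(=O)(=O)c3cccnc3)CC2)CC1`, gives 2400 nM in a functional assay on DLD-1 cells (Homo sapiens) for antiproliferative activity, read by CellTiter-Glo, with a stated time of 72 h; on this read-out higher numbers stand for weaker inhibition and lower numbers for stronger inhibition
- compound 2, `Cc1cc(C)c(S(=O)(=O)N2CCC(N3CCN(C)CC3)CC2)c(C)c1`, gives 1100 nM in this assay
- compound 3, `CC(=O)Nc1ccc(S(=O)(=O)N2CCC(N3CCC(C)CC3)CC2)c2ccccc12`, gives 1100 nM in this assay

All three share a sulfonamide built on a ring nitrogen, with an aromatic group on the sulfonyl sulfur. Among them compound 1 stands at the highest number, which on this read-out means the weakest inhibition of cell growth; both compound 2 and compound 3 sit lower by more than the usual scatter of repeated measurements, so the gap to compound 1 is a real one rather than noise.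

The step followed here leads from compound 1 to compound 4, `CC1CCN(C2CCN(S(=O)(=O)c3ccc(F)cc3F)CC2)CC1`, which has not yet been measured. The change is confined to the group on the sulfonyl sulfur: 2,4-difluorophenyl in place of pyridin-3-yl on a sulfonyl sulfur. The rest of the molecule is untouched.

Within the data shown here, no measured pair shows exactly this exchange, so the expectation rests on the whole set. Compound 2 and compound 3, each carrying a six-membered aromatic ring of carbon only on the sulfonyl sulfur, give lower numbers than compound 1. A modest improvement is therefore expected for compound 4, roughly a 1.8-fold lower number from compound 1 to compound 4 (0.27 log units; within the scatter), and its value in this assay is estimated at 1300 nM, with a likely range from 500 nM to 3500 nM.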

Compound 4, half-maximal inhibitory concentration: 102 nM
For compound 4 the middle estimate is 13-fold (1.11 log units) above the measured one, outside the stated range (below it).
By their numbers in this assay, from the lowest: compound 4; then compounds 2 and 3 (each within the scatter of the next); then compound 1.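

In this assay, putting 2,4-difluorophenyl in place of pyridin-3-yl on a sulfonyl sulfur gives a 24-fold lower number from compound 1 to compound 4 (1.37 log units; beyond the scatter), a large step well beyond the scatter of repeated measurements. The earlier compounds differ from one another in more than one place and could not isolate this group, whereas here the rest of the molecule stays the same, so the group on the sulfonyl sulfur alone accounts for the whole step. Nothing available here explains why the step is so large, and the exchange does several things at once, since the ring nitrogen leaves while fluorine enters, so neither part of the change can be credited on its own.

Going by these compounds, it remains open whether a plain phenyl group on the sulfonyl sulfur would land near compound 4 or near compound 1, a result that would help separate the loss of the ring nitrogen from the arrival of fluorine. On these data alone, it is also open whether the gain carries over to other molecules, since 2,4-difluorophenyl appears here only on the core of compound 1 and not with the other parts of compound 2 or compound 3.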